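A few compounds are considered here, and "the series" means these few. Any claim that something is new, unique, unknown or untested is made for them only; others in the source may bear on it.

Working notes on the series. The assay is a functional assay on EC17 cells (Homo sapiens) for inhibition, with a stated time of 24 h; a lower number here means a stronger inhibitor, a higher number a weaker inhibitor. Compound 1 `C=C(CC/C=C(\C)CCC=C(C)C)C(O)Cc1c(O)cc(C)c(C=O)c1O` gives 7530 nM in this assay. Compound 2 `C=C(CC[C@@]1(C)[C@H](C)CCC(=O)[C@@H]1C)[C@H](O)Cc1c(O)cc(C)c(C=O)c1O` gives 7220 nM. Compound 3 `C=C(CC[C@H]1[C@@H](C)CCCC1(C)C)C(O)Cc1c(OC)cc(C)c(C=O)c1O` gives 4570 nM. Compound 1 has the highest of the three numbers, but its gaps to compound 2 and to compound 3 both lie within the scatter of repeated runs, so the three measured compounds cannot be ranked against one another on these numbers.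

The next compound, compound 4 `C=C(CCc1c(C)cccc1C)C(O)Cc1c(O)cc(C)c(C=O)c1O`, is not yet measured. It differs from compound 1 in one place: 2,6-dimethylphenyl in place of 2,6-dimethylhepta-1,5-dien-1-yl on a saturated chain carbon, two bonds along the chain from a double-bonded chain carbon. The rest of the shared core is unchanged.

Within the data shown here, no step between two measured compounds is available to calibrate this exchange; the three measured compounds vary elsewhere and agree within the scatter. The expected step of a 1.2-fold lower number from compound 1 to compound 4 (0.06 log units; within the scatter) is therefore small and within the scatter, with no direction favoured. Compound 4 is expected to give 6500 nM in this assay, estimated within the range 2500 nM to 17000 nM.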

Compound 4, half-maximal inhibitory concentration: 10600 nM
Beside the measured number, compound 4's estimate is 1.6-fold (0.21 log units) below it; measured number inside the range.
By their numbers in this assay, from the lowest: compounds 3, 2, 1 and 4 (each within the scatter of the next, the first and the last beyond it).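

In this assay, among these compounds, the step of a 1.4-fold higher number from compound 1 to compound 4 (0.15 log units; within the scatter) is the first direct reading of a single exchange, and it lies within the scatter. At this saturated chain carbon, 2,6-dimethylphenyl, with its six-membered aromatic ring of carbon only, therefore cannot be told apart from the open-chain 2,6-dimethylhepta-1,5-dien-1-yl, which has no ring and two double bonds. This one pair offers no measured information on why the two groups read alike.

The compounds shown leave open whether any group at this place can move the number beyond the scatter, for instance an unsubstituted phenyl, a pyridine ring, an amine or a carboxylic acid. Going by these compounds, it also remains open how a longer chain between this ring and the double-bonded chain carbon would read.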